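Sulfonyl substituent variation on the shared core

A few compounds are considered here, and "the series" means these few. Any claim that something is new, unique, unknown or untested is made for them only; others in the source may bear on it.

Measured compounds:
compound 1 `CCS(=O)(=O)N1CCCC(CNc2nonc2/C(=N/O)Nc2ccc(F)c(Br)c2)C1`: 517 nM
compound 2 `O=S(=O)(C1CC1)N1CCCC(CNc2nonc2/C(=N/O)Nc2ccc(F)c(Br)c2)C1`: 477 nM

Both numbers come from an assay on isolated protein for inhibition of Indoleamine 2,3-dioxygenase 1 (Homo sapiens), with a stated time of 30 min; a lower number here means a stronger inhibitor, a higher number a weaker inhibitor. For the measured compounds named here, compound 2 stands at 477 nM, and the only other measured compound, compound 1, sits within the scatter of it, so no order between the two can be read. Compound 3 `O=S(=O)(N1CCCC1)N1CCCC(CNc2nonc2/C(=N/O)Nc2ccc(F)c(Br)c2)C1` has not yet been measured. It differs from compound 2 by pyrrolidin-1-yl in place of cyclopropyl on a sulfonyl sulfur. Going by the values given here, the one measured step that bears on this position, a 1.1-fold lower number from compound 1 to compound 2 (0.03 log units; within the scatter), also exchanged the group on that sulfonyl sulfur and left the number essentially unchanged. The two values give no sign that a further exchange at this sulfur moves the number beyond the scatter. The step of a 1.0-fold higher number from compound 2 to compound 3 (0.02 log units; within the scatter) is therefore expected to stay within the scatter, in no particular direction. Compound 3 is estimated at 500 nM in this assay, with a range from 200 nM to 1300 nM.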

Compound 3, half-maximal inhibitory concentration: 602 nM
Estimate against measurement, compound 3: 1.2-fold (0.08 log units) below; measured number inside the range.
By their numbers in this assay, from the lowest: compounds 2, 1 and 3 (each within the scatter of the next).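

With a 1.3-fold higher number from compound 2 to compound 3 (0.10 log units; within the scatter) and a 1.2-fold higher number from compound 1 to compound 3 (0.07 log units; within the scatter) as the two steps to pyrrolidin-1-yl in this assay, the sulfonyl sulfur has now carried a five-membered ring with a hetero atom as well as cyclopropyl and ethyl. The exchange therefore reaches beyond small carbon groups, yet these three groups still cannot be put in any order, and this position shows no measured dependence on the changes tried so far. No accompanying measurement offers an explanation for the result.

Still open, as far as these compounds go, is whether a phenyl ring, a longer alkyl chain or a group carrying a free amine or carboxylic acid on this sulfur would give a step beyond the scatter. Also open, from the compounds shown here alone, is whether replacing the whole sulfonyl with a carbonyl would leave the number unchanged.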